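A few compounds are considered here, and "the series" means these few. Any claim that something is new, unique, unknown or untested is made for them only; others in the source may bear on it.

In a functional assay on U-87MG ATCC cells for antiproliferative activity against U-87 MG (Homo sapiens), read by MTT assay, with a stated time of 48 h, tested at 10 uM (a higher number here means a weaker effect of the compound at the concentration tested, a lower number a stronger effect), compound 1 `COc1ccc(-c2nc(C)c(C(=O)CSc3nc(N)c(C#N)c(-c4ccc(Cl)cc4)n3)s2)cc1` gives 44%. Compound 2 `COc1ccc(-c2nc(C)c(C(=O)CSc3nc(-c4cccc(OC)c4)c(C#N)c(=O)[nH]3)s2)cc1` gives 66.7%, and compound 3 `COc1cccc(-c2nc(SCC(=O)c3sc(-c4ccccc4)nc3C)[nH]c(=O)c2C#N)c1` gives 90.2%. The cores of compound 1 and compound 2 differ, but that difference is not broken down here. Compound 2 and compound 3 differ in one place: hydrogen in place of methoxy on an aromatic carbon. This change moved the read-out a number 23.5 percentage points higher from compound 2 to compound 3 (beyond the scatter), a weaker effect. Compound 4 `Cc1nc(-c2ccccc2)sc1C(=O)CSc1nc(N)c(C#N)c(-c2ccc(Cl)cc2)n1` has not yet been measured in this assay. It differs from compound 1 by the same change: hydrogen in place of methoxy on an aromatic carbon. Going by the values given here, because the one measured instance of this change gave a number 23.5 percentage points higher from compound 2 to compound 3 (beyond the scatter), a step of similar size, a number 19 percentage points higher from compound 1 to compound 4 (beyond the scatter), is expected here too, although this rests on a single pair. Compound 4 is therefore estimated to give about 63%, with a likely range from 46% to 80%.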

Compound 4, a percentage reported as activity, at one concentration (the size of the read-out at that concentration, not a potency): 58.8%
Estimate against measurement, compound 4: 4.2 percentage points above, within the range that was stated.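

Replacing methoxy with hydrogen also weakened the effect on the core of compound 1 in this assay, with a number 14.8 percentage points higher from compound 1 to compound 4 (beyond the scatter). Across the two cores, the change went the same way and the two steps did not differ in size beyond the scatter: the same change on two cores in this assay, a number 23.5 percentage points higher (beyond the scatter) from compound 2 to compound 3 and a number 14.8 percentage points higher (beyond the scatter) from compound 1 to compound 4, 8.7 percentage points apart, within the scatter of two such steps With only two pairs, this supports carrying the change between these two cores, but it does not show that the step would hold on any other core, nor does it explain why the step occurs.

The compounds shown carry only methoxy or hydrogen at this place, so the outcome with a hydroxyl group, a fluorine atom or a longer chain such as ethoxy remains open. Also open, from the compounds shown here alone, is whether the step would survive on a core with a carboxylic acid in place of the nitrile.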